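This account rests on a few compounds, and the source may have more. Where it says the series, first, only, none or still open, it means among the compounds named here.

Measured compounds in a functional assay on PA-1 cells (Homo sapiens) for cytotoxicity, read by MTT assay, with a stated time of 48 h; on this read-out lower numbers stand for stronger inhibition and higher numbers for weaker inhibition:
compound 1 `Cn1cc(/C=C2/C(=O)Nc3ccccc32)c2cc(Nc3nccc(-c4ccccc4)n3)ccc21` gives 17300 nM.
compound 2 `Cc1ccc(-c2ccnc(Nc3ccc4c(c3)c(/C=C3/C(=O)Nc5ccccc53)cn4C)n2)cc1` gives > 100000 nM; this is a limit of the assay, not a number.
compound 3 `COc1ccc(-c2ccnc(Nc3ccc4c(c3)c(/C=C3/C(=O)Nc5ccccc53)cn4C)n2)cc1` gives > 100000 nM; this too is a limit of the assay, not a number.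

Compound 3 thus stands at the limit of this assay, where two of the three values sit (the limit of > 100000 nM in this assay, at which 2 of the 3 values shown sit); only compound 1 returns a number. Compound 4 `Cn1cc(/C=C2/C(=O)Nc3ccccc32)c2cc(Nc3nccc(-c4ccc(O)cc4)n3)ccc21` differs from compound 3 by hydrogen in place of methyl on an oxygen on an aromatic ring. For the measured compounds named here, no measured step removes the methyl on that oxygen, so there is no direct parallel. The nearest steps are an at least 5.7-fold higher number from compound 1 to compound 3 (0.76 log units; beyond the scatter) and an at least 5.7-fold higher number from compound 1 to compound 2 (0.76 log units; beyond the scatter), both moving the number out to the limit; the step that the two limits leave unreadable from compound 2 to compound 3. Whether a hydroxy on the phenyl behaves like the methoxy and methyl or falls back toward compound 1 cannot be read from these three compounds. For compound 4 the expected step is an at least 1.6-fold lower number from compound 3 to compound 4 (0.22 log units; that floor lies within the scatter), measured against a limit. Compound 4 is estimated at 60000 nM in this assay, with a range from 15000 nM to 200000 nM.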

Compound 4, half-maximal inhibitory concentration: 9270 nM
Compound 4: the middle estimate sits 6.5-fold (0.81 log units) above what was measured; measured number outside the range, below it.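

Swapping methoxy for hydroxy on the phenyl gives an at least 10-fold lower number from compound 3 to compound 4 (1.03 log units; beyond the scatter) in this assay and replacing methyl with hydroxy gives an at least 10-fold lower number from compound 2 to compound 4 (1.03 log units; beyond the scatter) in the same read-out, so a group at this place does not always carry the number out to the limit. Hydroxy in place of hydrogen gives a 1.9-fold lower number from compound 1 to compound 4 (0.27 log units; within the scatter) and so sets no order between those two compounds, which makes 4-hydroxyphenyl the one substituted phenyl here that returns a number. Compound 2 and compound 3 each give a limit and not a number, so those two steps are floors: the limit of > 100000 nM in this assay, at which 2 of the 4 values shown sit.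

From the compounds shown here alone, whether an amine or a carboxylic acid in place of the hydroxy would also return a number stays open. So does whether a longer chain on that oxygen, such as ethoxy, would stay at the limit as methoxy does.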